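Methoxy in Place of Methyl on Compound 2

This account rests on a few compounds, and the source may have more. Where it says the series, first, only, none or still open, it means among the compounds named here.

In a functional assay on SK-BR-3 cells (Homo sapiens) for antiproliferative activity, with a stated time of 72 h (on this read-out lower numbers stand for stronger inhibition of growth and higher numbers for weaker inhibition of growth), compound 2 `Cc1ccc(CN(C)C(=O)c2cc(Cl)c(O)cc2O)cc1` gives 7200 nM. That value lies within the scatter of compound 3 `Cc1ccccc1CN(C)C(=O)c1cc(Cl)c(O)cc1O` at 4200 nM, while compound 1 `COc1cc(CN(C)C(=O)c2cc(Cl)c(O)cc2O)cc(OC)c1OC` at 30100 nM lies beyond the scatter on the higher side of compound 2. Compound 4 `COc1ccc(CN(C)C(=O)c2cc(Cl)c(O)cc2O)cc1` differs from compound 2 by methoxy in place of methyl on an aromatic carbon. Within the data shown here, no measured step makes this exchange. Among the measured compounds shown here, the one measured step, a 1.7-fold lower number from compound 2 to compound 3 (0.23 log units; within the scatter), only shifts the methyl. Compound 1 at 30100 nM carries methoxy groups, which gives weak support for a slightly higher number. The estimated step, a 1.3-fold higher number from compound 2 to compound 4 (0.10 log units; within the scatter), is expected to stay within the scatter. For compound 4 the expected value is 9000 nM, with an estimated range of 4000 nM to 20000 nM.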

Compound 4, concentration for 50% growth inhibition: 7200 nM
The estimate for compound 4 lay 1.3-fold (0.10 log units) above the measured number; the measured number falls inside the stated range.
By their numbers in this assay, from the lowest: compounds 3, 2 and 4 (each within the scatter of the next); then compound 1.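

In this assay, among these compounds, methoxy in place of methyl on an aromatic carbon, para to a large group, gives no change at the digits printed from compound 2 to compound 4 (within the scatter) and so offers the first direct reading of this exchange, since the earlier step only shifted the methyl. At this position, the added oxygen leaves the number where it was. Nothing available explains why the two groups read alike. The compounds shown leave open whether an amine, a carboxylic acid or a longer chain such as ethoxy at this position would also leave the number unchanged.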